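The source may hold more compounds than are shown below. What is called first, only, known or untested is meant among the compounds shown, and "the series" means these compounds.

In an assay on isolated protein for inhibition of DNA topoisomerase 1 (Homo sapiens), with a stated time of 30 min, tested at 20 uM (a lower number here means a weaker effect, a higher number a stronger effect of the compound at the concentration tested), compound 1 `Cc1cccc(-c2nc3cc(C)ccc3c(=O)[nH]2)c1` gives 56.3%, the highest of the three numbers measured here. Compound 2 `Cc1ccc2c(=O)[nH]c(-c3ccccc3C)nc2c1` shares the same atoms but joins them differently, and in this assay compound 2 gives 39.2%; the difference between the two cores is not broken down here. Compound 3 `Cc1ccc2c(=O)[nH]c(-c3ccccc3F)nc2c1` differs from compound 2 by fluoro in place of methyl on an aromatic carbon, and in this assay compound 3 gives 0%. That single change produced a number 39.2 percentage points lower from compound 2 to compound 3 (beyond the scatter).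

Compound 4 `Cc1ccc2c(=O)[nH]c(-c3cccc(F)c3)nc2c1` differs from compound 1 by fluoro in place of methyl on an aromatic carbon. This is the same kind of change as from compound 2 to compound 3, but the place is not identical: there the fluoro enters ortho to a large group, here it enters meta to a large group. Because the earlier step was a number 39.2 percentage points lower from compound 2 to compound 3 (beyond the scatter), a clear loss is expected from compound 1 as well, estimated as a number 36.3 percentage points lower from compound 1 to compound 4 (beyond the scatter), though the different place makes its size uncertain. Compound 4 is therefore expected to give about 20%, likely between 0% and 45%.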

Compound 4, a percentage reported as inhibition, at one concentration (the size of the read-out at that concentration, not a potency): 4.3%
For compound 4 the middle estimate is 15.7 percentage points above the measured one; the measured number falls inside the stated range.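

In this assay the swap of methyl for fluoro again costs most of the effect, with a number 52 percentage points lower from compound 1 to compound 4 (beyond the scatter) on this second pair of compounds. Although the change sits at a different place on the ring in each pair, the two steps cannot be told apart: the same change on two cores in this assay, a number 39.2 percentage points lower (beyond the scatter) from compound 2 to compound 3 and a number 52 percentage points lower (beyond the scatter) from compound 1 to compound 4, 12.8 percentage points apart, within the scatter of two such steps. This shows that the loss carried over between these two pairs, but two pairs do not make a rule for the whole series, and these numbers do not explain why fluoro does so much worse than methyl.

Going by these compounds, it remains open whether another group at these places on the ring, such as chloro, methoxy or an amine, would keep the effect that methyl gives. On these data alone, it is also open whether the same swap would cost as much at any other place on the ring, or whether the methyl on the shared core matters for the effect.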